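This account rests on a few compounds, and the source may have more. Where it says the series, first, only, none or still open, it means among the compounds named here.

Compound 3, `CCCCCCc1cn([C@H]2C[C@@H]3OP(=O)(O)OC[C@H]3O2)c(=O)[nH]c1=O`, reaches only the limit of a functional assay on Raji cells (Homo sapiens) (on this read-out lower numbers stand for stronger inhibition and higher numbers for weaker inhibition), giving > 500 ug/mL. Compound 1, `CCc1cn([C@H]2C[C@@H]3OP(=O)(O)OC[C@H]3O2)c(=O)[nH]c1=O`, likewise stops at a limit in this assay, with > 500 ug/mL. Going by the values given here, compound 2, `CCCCCCCCc1cn([C@H]2C[C@@H]3OP(=O)(O)OC[C@H]3O2)c(=O)[nH]c1=O`, is the one member of this small set with a number, 184 ug/mL. Among the shown steps, an at least 2.7-fold lower number from compound 1 to compound 2 (0.43 log units; beyond the scatter) and an at least 2.7-fold higher number from compound 2 to compound 3 (0.43 log units; beyond the scatter) are readable, while a step that the two limits leave unreadable from compound 1 to compound 3, because both ends sit at the limit of > 500 ug/mL in this assay, at which 2 of the 3 values shown sit.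

Compound 4, `CCCc1cn([C@H]2C[C@@H]3OP(=O)(O)OC[C@H]3O2)c(=O)[nH]c1=O`, differs from compound 3 by hydrogen in place of propyl on a saturated chain carbon, three bonds along the chain from an aromatic carbon. That places compound 4 between compound 1 and compound 3 in chain length, and both of those sit at the limit, so compound 4 is expected to stay there too, with a step that the limit leaves unreadable from compound 3 to compound 4. The estimate for compound 4 is 900 ug/mL, ranging from 400 ug/mL to 3000 ug/mL.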

Compound 4, concentration for 50% inhibition: > 500 ug/mL
Compound 4: only a limit was reported; the forecaster's own chance of this, stated with the estimate: 85%; the middle value lies beyond the limit too.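

Replacing pentyl with hydrogen on the chain of compound 2 gives an at least 2.7-fold higher number from compound 2 to compound 4 (0.43 log units; beyond the scatter) in this assay, so compound 2, with the longest chain shown, remains the only one with a number. Compound 4 adds no ranking among the shorter chains. The steps among compound 1, compound 3 and compound 4 cannot be read, because all three values are limits and not numbers: the limit of > 500 ug/mL in this assay, at which 3 of the 4 values shown sit.

Open, on these data alone, is whether a chain longer than that of compound 2 would lower the number further. Also open, as far as these compounds go, is what an amine or a carboxylic acid at the end of the chain would do.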